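Quinazolinyl acylthiosemicarbazides: methyl in place of trifluoromethyl

A few compounds are considered here, and "the series" means these few. Any claim that something is new, unique, unknown or untested is made for them only; others in the source may bear on it.

Series on the shared core of compound 1 `COc1ccccc1C(=O)NC(=S)NNc1ncnc2ccccc12`, compound 2 `O=C(NC(=S)NNc1ncnc2ccccc12)c1ccc(F)cc1` and compound 3 `O=C(NC(=S)NNc1ncnc2ccccc12)c1ccc(C(F)(F)F)cc1`. In a functional assay on CNE-2 cells (Homo sapiens) for cytotoxicity, read by MTT assay, with a stated time of 72 h (on this read-out higher numbers stand for weaker inhibition and lower numbers for stronger inhibition), compound 1 gives 15700 nM, compound 2 gives 2840 nM and compound 3 gives 22500 nM, the highest of the three; compound 1 sits within the scatter of it, compound 2 well beyond. The measured steps are a 5.5-fold lower number from compound 1 to compound 2 (0.74 log units; beyond the scatter) and a 7.9-fold higher number from compound 2 to compound 3 (0.90 log units; beyond the scatter). Compound 4 `Cc1ccc(C(=O)NC(=S)NNc2ncnc3ccccc23)cc1` is the next case: methyl in place of trifluoromethyl on an aromatic carbon. Among the compounds with values here, only the step from compound 2 to compound 3 bears directly on a change at this position, and it moved the number modestly; a smaller step in the other direction is expected, a 2.5-fold lower number from compound 3 to compound 4 (0.40 log units; beyond the scatter). Compound 4 is estimated at 9000 nM in this assay, within 3000 nM to 27000 nM.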

Compound 4, half-maximal inhibitory concentration: 17200 nM
Beside the measured number, compound 4's estimate is 1.9-fold (0.28 log units) below it; the range from low to high includes it.
By their numbers in this assay, from the lowest: compound 2; then compounds 1, 4 and 3 (each within the scatter of the next).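

In this assay, methyl and trifluoromethyl on this aromatic carbon cannot be told apart (a 1.3-fold lower number from compound 3 to compound 4 (0.12 log units; within the scatter)). Fluoro alone stands apart from both groups at this position (a 6.1-fold higher number from compound 2 to compound 4 (0.78 log units; beyond the scatter)), and the change to 4-methylphenyl from 2-methoxyphenyl on the carbonyl carbon stays within the scatter (a 1.1-fold higher number from compound 1 to compound 4 (0.04 log units; within the scatter)). No supporting evidence bears on this result.

Open, from the compounds shown here alone, is whether chloro at this position would track fluoro or the two larger groups. Also open, going by these compounds, is whether an amine or a carboxylic acid there would separate from methyl.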